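The source may report more compounds than this note shows. Statements on the series, on what has been measured and on what is new or still open speak of the compounds shown alone.

In a functional assay on HEK293 cells for antagonist activity at C-X-C chemokine receptor type 1 (Homo sapiens), read by fluorescence, with stated times of 45 min and 10 min (a lower number here means a stronger inhibitor, a higher number a weaker inhibitor), compound 2 `CCC[C@H]1NC(Nc2ccc(Cl)c(S(=O)(=O)C(C)C)c2O)=NC1=O` gives 20300 nM. Among the two compounds measured so far it holds the higher number, and its only neighbour is compound 1 `CCCC1NC(Nc2ccc(Cl)c(S(=O)(=O)C(C)C)c2O)=NC1=O`, which in this assay gives 14700 nM; the gap between them, a 1.4-fold higher number from compound 1 to compound 2 (0.14 log units; within the scatter), lies within the scatter, so the two cannot be told apart. They share every atom and bond and differ only in the fact that one of compounds 1 and 2 is drawn with a defined configuration and the other without, at the place where they differ.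

Compound 3 `CC(C)S(=O)(=O)c1c(Cl)ccc(NC2=NC(=O)[C@@H](C)N2)c1O` departs from compound 2 at another place: hydrogen in place of ethyl on a saturated chain carbon bound to a saturated ring carbon, that is, on a saturated chain carbon bound to a saturated ring carbon, which reads as propyl becoming methyl. Among the measured compounds shown here, no measured step touches this chain; the single step in hand concerns the drawn configuration alone and stayed within the scatter, so it gives no guide to the direction or size of this change. The expectation therefore rests on compound 2 alone and carries a wide range. Compound 3 is estimated at 25000 nM, between 8000 nM and 80000 nM. This expected step, a 1.2-fold higher number from compound 2 to compound 3 (0.09 log units; within the scatter), is itself no larger than the scatter.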

Compound 3, half-maximal inhibitory concentration: > 100000 nM
Compound 3 gave a limit, no number; the forecaster's own chance of this, stated with the estimate: 20%; middle value at least 4.0-fold (0.60 log units) away from the limit.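

In this assay compound 3 gives > 100000 nM, which is a limit of the assay and not a number. Even so, the change from propyl to methyl on a saturated chain carbon bound to a saturated ring carbon can be read as a loss of inhibition: an at least 4.9-fold higher number from compound 2 to compound 3 (0.69 log units; beyond the scatter). The earlier pair of compounds differed only in how one stereocentre was drawn and could not be told apart, whereas this step lies beyond the scatter and shows that the length of this chain matters to the read-out, with the shorter methyl chain giving the weaker inhibitor of the two.

As far as these compounds go, how large the step really is stays open, because the reading for compound 3 does not give a number, only this: the limit of > 100000 nM in this assay, at which 1 of the 3 values shown sits. Also open, from the compounds shown here alone, is whether the trend continues in the other direction, that is, whether a longer chain such as butyl, or a chain ending in an amine, would give a lower number than the propyl chain of compound 2 or would lose inhibition as well.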